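Notes toward compound 4 in the shared core series

The compounds below may be only part of what the source reports. "The series", "measured", "known", "first", "only" and "open" are said of these compounds alone.

Three compounds share one core. Compound 1 `Cc1nn(-c2ncnc3nc[nH]c23)c2c1C(c1ccc(F)cc1Cl)CC(=O)N2` gives 9 nM in a functional assay on HEK293 cells for agonist activity at G-protein coupled receptor 39 (Homo sapiens), read by scintillation proximity assay and inositol phosphate accumulation, with a stated time of 75 min, in the presence of a further agent that is not named here; on this read-out lower numbers stand for an effect already at smaller amounts and higher numbers for an effect only at larger amounts of compound. Compound 2 `Cc1nn(-c2ncnc3nc[nH]c23)c2c1C(OCc1ccccc1Cl)CC(=O)N2` gives 2 nM there, and compound 3 `Cc1nn(-c2ncnc3nc[nH]c23)c2c1C(OC(=O)c1ccc(F)cc1)CC(=O)N2` gives 4 nM. Compound 3 thus holds the second highest of the three numbers: the gap a 2.0-fold higher number from compound 2 to compound 3 (0.30 log units; within the scatter) is within the scatter, while a 2.3-fold lower number from compound 1 to compound 3 (0.35 log units; beyond the scatter) lies beyond it. Compound 4 `Cc1nn(-c2ncnc3nc[nH]c23)c2c1C(C(=O)Nc1ccccc1)CC(=O)N2` awaits measurement; it carries phenylcarbamoyl in place of ((4-fluorophenyl)carbonyl)oxy on a saturated ring carbon. Within the data shown here, no measured step covers this exchange directly; the nearest comparisons are a 2.0-fold higher number from compound 2 to compound 3 (0.30 log units; within the scatter) and a 2.3-fold lower number from compound 1 to compound 3 (0.35 log units; beyond the scatter), both modest, and all three known numbers sit close together. A small step is therefore expected, probably none beyond the scatter, which is the meaning of a 1.5-fold higher number from compound 3 to compound 4 (0.18 log units; within the scatter). Compound 4 is estimated at 6 nM, with a range from 1.5 nM to 25 nM.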

Compound 4, half-maximal effective concentration: 10 nM
For compound 4 the middle estimate is 1.7-fold (0.22 log units) below the measured one; low and high end bracket the measured number.
By their numbers in this assay, from the lowest: compounds 2 and 3 (each within the scatter of the next); then compounds 1 and 4 (each within the scatter of the next).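

Exchanging ((4-fluorophenyl)carbonyl)oxy for phenylcarbamoyl, which adds a hydrogen-bond donor on this saturated ring carbon, gives a modest loss (a 2.5-fold higher number from compound 3 to compound 4 (0.40 log units; beyond the scatter)), and the loss from the (2-chlorobenzyl)oxy compound is larger (a 5.0-fold higher number from compound 2 to compound 4 (0.70 log units; beyond the scatter)). Against 2-chloro-4-fluorophenyl, phenylcarbamoyl shows no real change (a 1.1-fold higher number from compound 1 to compound 4 (0.05 log units; within the scatter)). Nothing measured here accounts for these steps.

Open, from the compounds shown here alone, is whether a carboxylic acid or a primary amine on this carbon stays in the same range. Also open, going by these compounds, is whether a chlorine on the phenyl of phenylcarbamoyl alters the number.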